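Compound 2 Trades Its Side Chain for 4-Methylpiperazin-1-yl

A few compounds are considered here, and "the series" means these few. Any claim that something is new, unique, unknown or untested is made for them only; others in the source may bear on it.

Two related compounds have been tested so far in a functional assay on MCF7 cells (Homo sapiens) for cytotoxicity; a lower number here means a stronger inhibitor, a higher number a weaker inhibitor. Compound 1 (`N=c1c2c(=S)n(-c3ccccc3)c(=S)n(-c3ccccc3)c2nc(NCc2ccccn2)n1-c1ccccc1`) gives > 50000 nM, which is a limit of the assay and not a number. Compound 2 (`N=c1c2c(=S)n(-c3ccccc3)c(=S)n(-c3ccccc3)c2nc(NCCCn2ccnc2)n1-c1ccccc1`) gives > 100000 nM, and this too is a limit. Neither compound therefore has an exact value to stand on.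

Compound 3 (`CN1CCN(c2nc3c(c(=N)n2-c2ccccc2)c(=S)n(-c2ccccc2)c(=S)n3-c2ccccc2)CC1`) keeps the shared core of compound 2 and changes one place. It has 4-methylpiperazin-1-yl in place of (3-(1H-imidazol-1-yl)propyl)amino on an aromatic carbon, between two ring nitrogen atoms (4-methylpiperazin-1-yl in place of (3-(1H-imidazol-1-yl)propyl)amino on an aromatic carbon).

Among the measured compounds shown here, only one measured step bears on this change, and it is a step that the two limits leave unreadable from compound 1 to compound 2. It offers no size to carry forward and no direction to follow. The starting point is thus just the limit of compound 2 at > 100000 nM, so no change beyond the usual scatter is expected in this assay. The expected step is an at least 1.2-fold lower number from compound 2 to compound 3 (0.09 log units; that floor lies within the scatter). The estimate for compound 3 is 80000 nM, with an expected range from 30000 nM to 150000 nM.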

Compound 3, half-maximal inhibitory concentration: > 50000 nM
Compound 3 was reported as a limit; the forecaster's own chance of this, stated with the estimate: 70%; the middle value is on the limit's open side.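

In this assay, among the compounds shown here, compound 1, compound 2 and compound 3 are all reported as limits and not as numbers, so no step among them can be read. The compounds shown leave open what exact value any of the three would give, and whether changing the group on the shared core alters that value at all.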